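Swapping the Carbonyl Arm for a Small Polar Group

A few compounds are considered here, and "the series" means these few. Any claim that something is new, unique, unknown or untested is made for them only; others in the source may bear on it.

Compound 1 `CC1(C)C=C(n2ccccc2=O)c2cc(C(=O)c3ccco3)ccc2O1`: 6.49
Compound 2 `CC1(C)C=C(n2ccccc2=O)c2cc(C(=O)c3ccccc3F)ccc2O1`: 7.08

In a functional assay (aorta) with Rattus norvegicus as the target (on this read-out higher numbers stand for higher potency (the scale is a negative logarithm) and lower numbers for lower potency), compound 2 stands highest of the two numbers shown, with compound 1 the nearest and lower, as the step of a number 0.59 log units higher from compound 1 to compound 2 (beyond the scatter) records. Compound 3 `CC1(C)C=C(n2ccccc2=O)c2cc(C(=N)NO)ccc2O1` differs from compound 2 in one place: a group of 4 heavy atoms (1 carbon, 2 nitrogen, 1 oxygen; no ring) in place of a group of 9 heavy atoms (7 carbon, 1 oxygen, 1 fluorine; one six-membered aromatic ring of carbon only), on an aromatic carbon. No measured step mirrors this change; the only step shown, a number 0.59 log units higher from compound 1 to compound 2 (beyond the scatter), swaps one aryl group for another while the carbonyl remains. With so large a replacement, a decrease beyond the scatter is expected, a number 1.48 log units lower from compound 2 to compound 3 (beyond the scatter). Compound 3 is therefore estimated at 5.6, within a range from 4.6 to 6.6.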

Compound 3, logarithm of the reciprocal of the active concentration, log(1/C): 5.99
For compound 3 the middle estimate is 0.39 log units below the measured one, and the stated range covers the measured number.
By their numbers in this assay, from the lowest: compound 3; then compound 1; then compound 2.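

In this assay, replacing the (2-fluorophenyl)carbonyl arm on this aromatic carbon with the small ring-free group gives a number 1.09 log units lower from compound 2 to compound 3 (beyond the scatter) and so moves the number further than the earlier aryl exchange did. Measured against the furan-2-yl carbonyl arm, the same group gives a number 0.50 log units lower from compound 1 to compound 3 (beyond the scatter) and thus falls below both aryl carbonyl compounds, though by a smaller step. Nothing available explains these drops. As far as these compounds go, whether a nitrile or a carboxylic acid on this carbon would match the group in compound 3 remains open, as does how a simple methyl ketone would compare with the aryl carbonyl arms.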